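The source may report more compounds than this note shows. Statements on the series, on what has been measured and on what is new or still open speak of the compounds shown alone.

Measured compounds in this set:

compound 1 `CC1CN(C(=O)c2ccc(-c3ccc(NC(=O)Nc4ccc(Cl)c(C(F)(F)F)c4)cc3)cc2)CC(C)O1` — 41900 nM
compound 2 `CC(NC(=O)CCc1ccc(NC(=O)Nc2ccc(Cl)c(C(F)(F)F)c2)cc1)c1ccccc1` — > 50000 nM
compound 3 `O=C(CCc1ccc(NC(=O)Nc2ccc(Cl)c(C(F)(F)F)c2)cc1)NC1CCC1` — > 50000 nM

For the measured compounds named here, in a functional assay on KETR3 cells (Homo sapiens) for inhibition, read by MTT assay, with a stated time of 120 h (on this read-out lower numbers stand for stronger inhibition and higher numbers for weaker inhibition), compound 1 gives 41900 nM, the only number among the three values. Compound 2 gives > 50000 nM, which is a limit of the assay. Compound 3 gives > 50000 nM, likewise a limit. Going by the values given here, the one single-point step, a step that the two limits leave unreadable from compound 2 to compound 3, therefore cannot be read; both ends sit at the limit of > 50000 nM in this assay, at which 2 of the 3 values shown sit.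

Compound 4 `CC(NC(=O)c1ccc(-c2ccc(NC(=O)Nc3ccc(Cl)c(C(F)(F)F)c3)cc2)cc1)c1ccccc1` differs from compound 1 by (1-phenylethyl)amino in place of 2,6-dimethylmorpholin-4-yl on a carbonyl carbon. Among the compounds with values here, no measured step covers this change on the shared core of compound 1. Compound 2 carries the same (1-phenylethyl)amino group on a carbonyl, but on a different core, so its limit gives no readable size for the step. With nothing beyond the scatter demonstrated anywhere in the set, the step from compound 1 to compound 4 is expected to be small, a 1.1-fold higher number from compound 1 to compound 4 (0.03 log units; within the scatter), with a real chance that this assay returns only a limit. Compound 4 is estimated at 45000 nM, within 15000 nM to 120000 nM.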

Compound 4, half-maximal inhibitory concentration: 19300 nM
Compound 4: middle estimate off by 2.3-fold (0.37 log units), on the high side; the measured number falls inside the stated range.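

For the compounds shown here, the change to (1-phenylethyl)amino in place of 2,6-dimethylmorpholin-4-yl on a carbonyl carbon gives a 2.2-fold lower number from compound 1 to compound 4 (0.34 log units; beyond the scatter) in this assay, the first readable step in the set, so the group on this carbonyl carbon does register on the shared core. The entering group differs from the leaving one in several counted features at once, including its aromatic ring of carbon only and its hydrogen-bond donor, and this single step does not separate them. The step between compound 2 and compound 3 cannot be read, so the other core offers no comparison, and the limit remains close: the limit of > 50000 nM in this assay, at which 2 of the 4 values shown sit.

Open, going by these compounds, is whether benzylamino or unsubstituted morpholin-4-yl on the same carbonyl carbon would follow compound 4 or compound 1. Also open, on these data alone, is whether a carboxylic acid or a longer chain at this place would lower the number further.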